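The source may report more compounds than this note shows. Statements on the series, on what has been measured and on what is new or still open speak of the compounds shown alone.

Compound 1 `CC1=NC(C)=C(C(=O)O)C(c2ccccc2)/C1=C(\O)OC/C=C/c1ccccc1` inhibits the channel in a functional assay on thoracic aorta for inhibition of Voltage-gated L-type calcium channel (Rattus norvegicus) (on this read-out lower numbers stand for stronger inhibition and higher numbers for weaker inhibition), with a value of 9 nM. Compound 2 `CC1=NC(C)=C(C(=O)O)C(c2cccc(C(=O)O)c2)/C1=C(\O)OC/C=C/c1ccccc1` carries carboxy in place of hydrogen on an aromatic carbon. For compound 2, this assay reports only a limit, > 10000 nM. The step of an at least 1100-fold higher number from compound 1 to compound 2 (3.04 log units; beyond the scatter) is therefore a lower bound, resting on (the limit of > 10000 nM in this assay, at which 1 of the 2 values shown sits). Compound 3 `CC1=NC(C)=C(C(=O)O)C(c2cccc(C)c2)/C1=C(\O)OC/C=C/c1ccccc1` differs from compound 2 by methyl in place of carboxy on an aromatic carbon. Because compound 1 gives 9 nM in this assay, compound 3 is expected to return close to it, a step of an at least 660-fold lower number from compound 2 to compound 3 (2.82 log units; beyond the scatter) toward stronger inhibition. Compound 3 is estimated at 15 nM, within 3 nM to 150 nM.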

Compound 3, half-maximal inhibitory concentration: 76 nM
For compound 3 the middle estimate is 5.1-fold (0.70 log units) below the measured one, and the stated range covers the measured number.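

In this assay, the change from carboxy to methyl gives an at least 130-fold lower number from compound 2 to compound 3 (2.11 log units; beyond the scatter), so the loss seen with carboxy is not shared by every group at this place on the ring. That step is only a lower bound: the limit of > 10000 nM in this assay, at which 1 of the 3 values shown sits. Methyl is still not equal to hydrogen here, with an 8.4-fold higher number from compound 1 to compound 3 (0.93 log units; beyond the scatter), so this place accepts a small carbon group, though with a modest loss of strength. Open, on these data alone, is how an amine, a hydroxymethyl group or a methyl ester would behave here, and whether a longer chain would lose more.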